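The source may report more compounds than this note shows. Statements on the series, on what has been measured and on what is new or still open speak of the compounds shown alone.

The three compounds measured so far, with their values in a functional assay on MCF7 cells (Homo sapiens) for inhibition, read by MTT assay, with stated times of 18 h and 4 h; on this read-out higher numbers stand for weaker inhibition and lower numbers for stronger inhibition:

Compound 1, `CCCOP(=O)(O)OCCSC(=S)N1CCCC1`, gives 73000 nM.
Compound 2, `CCCCCCOP(=O)(O)OCCSC(=S)N1CCCCCC1`, gives 55000 nM.
Compound 3, `CCCCCCOP(=O)(O)OCCSC(=S)N1CCCC1`, gives 100000 nM.

All three share one backbone: a phosphate ester carrying a chain on one side and a sulfur-linked dithiocarbamate on the other, closed by a saturated nitrogen ring. They differ in two places only. Between compound 3 and compound 2 the ring changes: azepan-1-yl in place of pyrrolidin-1-yl on a thiocarbonyl carbon. The step this made was a 1.8-fold higher number from compound 2 to compound 3 (0.26 log units; within the scatter). Between compound 3 and compound 1 the chain is shortened: hydrogen in place of propyl on a saturated chain carbon, three bonds along the chain from an oxygen on an unsaturated carbon. That step was a 1.4-fold lower number from compound 3 to compound 1 (0.14 log units; within the scatter). Every gap among the three numbers lies within the usual scatter, so none of the three stands apart from the others in this assay.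

Compound 4, `CCCOP(=O)(O)OCCSC(=S)N1CCCCCC1`, has not yet been measured. It is reached from compound 2 by the same change that led from compound 3 to compound 1: hydrogen in place of propyl on a saturated chain carbon, three bonds along the chain from an oxygen on an unsaturated carbon. The surroundings of the change are identical in both pairs, so this is the same change, made on the core that carries the seven-membered ring instead of the five-membered one.

Because the step of a 1.4-fold lower number from compound 3 to compound 1 (0.14 log units; within the scatter) was within the scatter, the chain shortening is expected to move compound 4 only a little, by about a 1.2-fold lower number from compound 2 to compound 4 (0.09 log units; within the scatter). Compound 4 is therefore estimated at 45000 nM in this assay. The expected range for compound 4 runs from 20000 nM to 100000 nM.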

Compound 4, half-maximal inhibitory concentration: 74000 nM
Beside the measured number, compound 4's estimate is 1.6-fold (0.22 log units) below it; measured number inside the range.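

In this assay, shortening the hexyl chain to propyl on the core of compound 2 gave a 1.3-fold higher number from compound 2 to compound 4 (0.13 log units; within the scatter). Set beside the same change on the core of compound 3, this step gives no sign that the effect of the change depends on the core: the same change on two cores in this assay, a 1.4-fold lower number (0.14 log units; within the scatter) from compound 3 to compound 1 and a 1.3-fold higher number (0.13 log units; within the scatter) from compound 2 to compound 4, 1.8-fold (0.27 log units) apart, within the scatter of two such steps. So, within the limits of this assay, the change could be carried from one core to the other and the result stayed within the usual noise of the measurement, but two pairs cannot show that the chain has no influence at all, nor that the two steps truly run in different directions.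

The compounds shown cover only the propyl and hexyl chains, so they leave open what this assay would report for a longer chain, such as decyl, or for a chain ending in an amine or a carboxylic acid. They also leave open whether the same chain change would behave alike on a core carrying an open diethylamino group in place of the saturated nitrogen ring.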